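The source may hold more compounds than are shown below. What is called first, only, known or untested is meant among the compounds shown, and "the series" means these compounds.

Within the data shown here, in an ADME assay on HepG2 2.2.15 cells (Homo sapiens) for cytotoxicity, read by MTT assay, with a stated time of 8 days (a lower number here means that less compound is tolerated, a higher number that more compound is tolerated), compound 1 `O=c1c(C2CC2)cc(-c2ccc(F)nc2F)nn1Cc1ccc(Cl)cc1` gives 39800 nM, the only true number among the three compounds measured so far. Compound 2 `Cc1nc(-c2ccc(F)nc2F)cn(Cc2ccc(Cl)cc2)c1=O` is reported as > 100000 nM, which is a limit and not a number. Compound 3 `COCCNc1ccc(-c2nn(Cc3ccc(C#N)cc3)c(=O)c3ccccc23)c(F)n1` is likewise reported as > 100000 nM, again a limit. Compound 1 therefore lies under both limits, and no finer ranking of the three can be given.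

Compound 4 `Cc1cc(-c2ccc(F)nc2F)nn(Cc2ccc(Cl)cc2)c1=O` keeps the core of compound 1, with its 2,6-difluoropyridin-3-yl and 4-chlorobenzyl groups, and carries methyl in place of cyclopropyl on an aromatic carbon, opposite the ring nitrogen: methyl in place of cyclopropyl on an aromatic carbon. Among the measured compounds shown here, no measured pair isolates this change, so any forecast rests on thin ground. The nearest guide is compound 2, which carries methyl and the same two groups on another core and stands at the limit of > 100000 nM. In this assay a small rise is therefore expected, toward more compound tolerated and not clearly beyond the scatter. The expected change is a 1.9-fold higher number from compound 1 to compound 4 (0.28 log units; within the scatter). Compound 4 is estimated at 75000 nM, with an expected range of 35000 nM to 160000 nM.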

Compound 4, half-maximal cytotoxic concentration: 83800 nM
Compound 4: the middle estimate sits 1.1-fold (0.05 log units) below what was measured; the measured number falls inside the stated range.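

In this assay, among these compounds, methyl in place of cyclopropyl on an aromatic carbon, opposite the ring nitrogen, gives the first step that can be read at this position: a 2.1-fold higher number from compound 1 to compound 4 (0.32 log units; beyond the scatter). The step is modest, but it shows that this position is not indifferent to the group it carries: with the 2,6-difluoropyridin-3-yl and 4-chlorobenzyl groups unchanged, the loss of the three-membered ring and the drop from 3 heavy atoms to 1 go with more compound tolerated. Any further rise from changes at this position could be followed only a short way, because the readings in this assay end at a limit: the limit of > 100000 nM in this assay, at which 2 of the 4 values shown sit.

With a single step, the compounds shown cannot separate the loss of the ring from the loss of carbon atoms, since an open chain such as ethyl is not among them. As far as these compounds go, how an amine, a carboxylic acid or a longer chain would read at this position remains open, as does whether the same change would give a similar step with other groups elsewhere on the core.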